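A Repeated Substituent Swap on Two Related Cores

A few compounds are considered here, and "the series" means these few. Any claim that something is new, unique, unknown or untested is made for them only; others in the source may bear on it.

Of the compounds shown here, three have been measured in a functional assay on HepG2 cells (Homo sapiens) for cytotoxicity, read by MTT assay, with a stated time of 24 h; a lower number here means a stronger inhibitor, a higher number a weaker inhibitor. Compound 1 `N#Cc1ccc(S(=O)(=O)N2C/C(=C\c3cccnc3)C(=O)/C(=C/c3ccccc3F)C2)cc1` gives 6600 nM in this assay. Compound 2 `CC(=O)Nc1ccc(S(=O)(=O)N2C/C(=C\c3cccnc3)C(=O)/C(=C/c3ccccc3F)C2)cc1` differs from compound 1 in a single place: acetamido in place of cyano on an aromatic carbon In this assay compound 2 gives 4560 nM. The effect of that swap is small, since the result is a 1.4-fold lower number from compound 1 to compound 2 (0.16 log units; within the scatter), a step that does not stand out from the usual scatter of repeated measurements.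

Compound 3 `N#Cc1ccc(S(=O)(=O)N2C/C(=C\c3ccncc3)C(=O)/C(=C/c3ccccc3C(F)(F)F)C2)cc1` gives 5920 nM in this assay. The difference between the core of compound 3 and the core of compound 1 is not broken down here. Compound 3 sits close to the other two: its value and that of compound 1 are within the scatter of each other, as are its value and that of compound 2.

Compound 4 `CC(=O)Nc1ccc(S(=O)(=O)N2C/C(=C\c3ccncc3)C(=O)/C(=C/c3ccccc3C(F)(F)F)C2)cc1` has not been measured. It differs from compound 3 in one place: acetamido in place of cyano on an aromatic carbon The description of the place is the same word for word as for the swap from compound 1 to compound 2, so this is the same change made on a different core.

Within the data shown here, the expectation for compound 4 rests on the only measured example of this change, where the step of a 1.4-fold lower number from compound 1 to compound 2 (0.16 log units; within the scatter) stayed within the scatter. Compound 4 is therefore expected to give about 4500 nM in this assay, with a plausible range from 2200 nM to 9500 nM. Among the measured compounds shown here, this means an expected step of a 1.3-fold lower number from compound 3 to compound 4 (0.12 log units; within the scatter), small and unlikely to be distinguishable from repeat-measurement noise, with only one earlier instance to support it.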

Compound 4, half-maximal inhibitory concentration: 4840 nM
Compound 4: middle estimate off by 1.1-fold (0.03 log units), on the low side, within the range that was stated.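

In this assay, putting acetamido in place of cyano on the second core gives a 1.2-fold lower number from compound 3 to compound 4 (0.09 log units; within the scatter), so on this core too the swap leaves the value inside the usual scatter of repeated measurements. Set side by side, the two examples of the change agree with each other: the same change on two cores in this assay, a 1.4-fold lower number (0.16 log units; within the scatter) from compound 1 to compound 2 and a 1.2-fold lower number (0.09 log units; within the scatter) from compound 3 to compound 4, 1.2-fold (0.07 log units) apart, within the scatter of two such steps

This shows that, on these two cores, exchanging the 4-cyanophenyl group for the 4-acetamidophenyl group gives steps of similar size, neither of which can be told apart from measurement noise; it does not show that acetamido really lowers the number, and two pairs cannot show that the same would hold on a further core.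

As far as these compounds go, all four compounds carry either cyano or acetamido at this place, so it remains open whether a different group there, such as an amine, a carboxylic acid or a longer chain, would give a step beyond the scatter. No pair shown isolates what separates the core of compound 1 from the core of compound 3, so the contribution of each difference between those cores also remains open.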